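The compounds below may be only part of what the source reports. "The series", "measured", "known", "first", "only" and "open" are said of these compounds alone.

Measured so far:
Compound 1, `Nc1nnc(SC[C@H]2O[C@@H](OCc3noc(-c4ccc(Cl)cc4)n3)[C@@H]3OC4(CCCC4)O[C@@H]32)s1`: 16000 nM
Compound 2, `CC1(C)O[C@H]2[C@H](OCc3noc(-c4ccc([N+](=O)[O-])cc4)n3)O[C@H](CO)[C@H]2O1`: 99000 nM

Both were tested in a functional assay on HeLa cells (Homo sapiens) for antiproliferative activity, read by sulforhodamine B assay, with a stated time of 48 h; on this read-out higher numbers stand for weaker inhibition of growth and lower numbers for stronger inhibition of growth. Compound 1 has the lower of the two numbers; the gap to compound 2 is beyond the usual scatter, so compound 1 is the stronger inhibitor of growth of the pair. Compound 3, `Clc1ccc(-c2nc(CO[C@@H]3O[C@H](CSc4ncn[nH]4)[C@H]4OC5(CCCC5)O[C@@H]34)no2)cc1`, has not yet been measured in this assay. It differs from compound 1 in a single place: 1H-1,2,4-triazol-5-yl in place of 5-amino-1,3,4-thiadiazol-2-yl on a sulfur. For the measured compounds named here, no pair of measured compounds differs by this change alone, so its effect is not yet known from the data here. The expectation is therefore a step in this assay no larger than the scatter, in either direction, which the estimate expresses as a 1.3-fold higher number from compound 1 to compound 3 (0.10 log units; within the scatter). Compound 3 is expected to give about 20000 nM in this assay, with a likely range from 6000 nM to 60000 nM.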

Compound 3, concentration for 50% growth inhibition: 14000 nM
For compound 3 the middle estimate is 1.4-fold (0.15 log units) above the measured one; the measured number falls inside the stated range.
By their numbers in this assay, from the lowest: compounds 3 and 1 (each within the scatter of the next); then compound 2.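

In this assay, putting 1H-1,2,4-triazol-5-yl in place of 5-amino-1,3,4-thiadiazol-2-yl on the sulfur gives a 1.1-fold lower number from compound 1 to compound 3 (0.06 log units; within the scatter), so the two compounds cannot be told apart on this read-out. For the compounds shown here, this is the first information on this position: here, one five-membered aromatic ring can replace another without a change beyond the scatter, even though the amino group and the sulfur of the leaving ring are both lost. Nothing available explains why the step is so small.

On these data alone, both groups are five-membered aromatic rings, so it remains open whether a phenyl ring, a simple methyl group or a carboxylic acid on the sulfur would give a similar number. As far as these compounds go, it is also open whether the sulfur itself matters, for instance with an oxygen in its place.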